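Nitro for bromo on the benzyl group: cytotoxicity notes

The source may hold more compounds than are shown below. What is called first, only, known or untested is meant among the compounds shown, and "the series" means these compounds.

Compound 1 `COC(=O)c1ccc(NCc2cncn2Cc2ccccc2OC)cc1-c1ccccc1` carries a 2-methoxybenzyl group on the shared core; in a toxicity assay on NIH3T3 cells (Mus musculus) for cytotoxicity, read by resazurin assay (a lower number here means that less compound is needed, a higher number that more compound is needed for the effect), compound 1 gives "not determined" (no result reported). Compound 2 `COC(=O)c1ccc(NCc2cncn2Cc2ccc(Cl)cc2)cc1-c1ccccc1` carries a 4-chlorobenzyl group instead, and in this assay compound 2 gives 25000 nM. Compound 3 `COC(=O)c1ccc(NCc2cncn2Cc2ccc(Br)cc2)cc1-c1ccccc1` is the 4-bromobenzyl analogue. In this assay compound 3 reaches only a limit of the assay, > 10000 nM, so no single number stands for it. The step that the limit leaves unreadable from compound 2 to compound 3 cannot be sized because the limit of > 10000 nM in this assay, at which 1 of the 3 values shown sits, hides its end.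

Compound 4 `COC(=O)c1ccc(NCc2cncn2Cc2ccc([N+](=O)[O-])cc2)cc1-c1ccccc1` differs from compound 3 by nitro in place of bromo on an aromatic carbon. Going by the values given here, the only measured step that bears on this change is the one from compound 2 to compound 3, and its size is not readable. What the two measured values show is that compound 2 and compound 3 both sit at the weak end of this assay, so no step beyond the scatter is expected from the new change, in either direction. Compound 4 is therefore expected at 30000 nM, with a range of 10000 nM to 100000 nM. The expected step that the limit leaves unreadable from compound 3 to compound 4 is small, and a further limit rather than a number is the likelier outcome.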

Compound 4, half-maximal effective concentration: > 10000 nM
Compound 4 gave a limit, no number; the forecaster's own chance of this, stated with the estimate: 60%; the middle value is on the limit's open side.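

In this assay compound 4 gives > 10000 nM as a limit and not a number. Going by these compounds alone, no step among compound 2, compound 3 and compound 4 can be read, since the values end at a limit: the limit of > 10000 nM in this assay, at which 2 of the 4 values shown sit. The compounds shown leave open how far compound 3 and compound 4 lie from each other and from compound 2.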